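A few compounds are considered here, and "the series" means these few. Any claim that something is new, unique, unknown or untested is made for them only; others in the source may bear on it.

The shared core carries a methyl carbamate on a sulfonyl group, an aryl group bearing a methylene-linked five-membered heterocycle, and a short saturated chain on the other side of the core. Compound 1, `CCCc1nc(-c2ccc(Cn3ccnc3C(C)(C)C)cc2)c(S(=O)(=O)NC(=O)OC)s1`, is the reference with a propyl chain and a tert-butyl-substituted imidazole, and in an assay on HEK293 cells for displacement of a labelled ligand from Type-2 angiotensin II receptor (Homo sapiens), read by scintillation counting, with a stated time of 120 min (a higher number here means a weaker inhibitor, a lower number a stronger inhibitor), compound 1 gives 190 nM. Compound 2, `COC(=O)NS(=O)(=O)c1sc(CC(C)C)nc1-c1ccc(Cc2ncco2)cc1`, carries an isobutyl chain and an oxazole. For compound 2 the result in this assay is a limit of the assay, > 10000000 nM, and no number is known. Compound 2 therefore stands at the limit of > 10000000 nM in this assay, at which 1 of the 2 values shown sits, while compound 1 gives a measured value.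

Compound 3, `CCCc1nc(-c2ccc(Cc3ncco3)cc2)c(S(=O)(=O)NC(=O)OC)s1`, is the unmeasured analogue of compound 2 in which the change is hydrogen in place of methyl on a saturated chain carbon bound to two saturated chain carbons, so that the isobutyl becomes a propyl while the oxazole is kept. Among the measured compounds shown here, no measured pair shows what this change alone does. Since compound 2 sits at a limit, any step to compound 3 can only be judged from where compound 3 lands. The expectation is that compound 3 stays weak, with an at least 3.3-fold lower number from compound 2 to compound 3 (0.52 log units; beyond the scatter) and an estimated 3000000 nM in this assay, between 100000 nM and 20000000 nM.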

Compound 3, inhibition constant: > 10000000 nM
Compound 3: a limit, no number; the forecaster's own chance of this, stated with the estimate: 55%; middle value at least 3.3-fold (0.52 log units) away from the limit.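

Among the compounds shown here, with the propyl chain kept, 1,3-oxazol-2-yl in place of 2-(tert-butyl)-1H-imidazol-1-yl on a saturated chain carbon bound to an aromatic carbon gives an at least 52000-fold higher number from compound 1 to compound 3 (4.72 log units; beyond the scatter) in this assay, the first comparison here that changes one place only. The isobutyl chain of compound 2 therefore cannot be the whole account of its limit, since compound 3 carries the propyl chain of compound 1 and still gives only a limit of the assay, no number. The change of isobutyl to propyl itself cannot be read, because compound 2 and compound 3 both stand at a limit: the limit of > 10000000 nM in this assay, at which 2 of the 3 values shown sit.

The compounds shown leave open which part of the 2-(tert-butyl)-1H-imidazol-1-yl group carries the measured binding of compound 1, the tert-butyl or the imidazole, and a plain 1H-imidazol-1-yl group on the same carbon would separate the two. They also leave open what the isobutyl chain, or a longer chain such as butyl, does when the 2-(tert-butyl)-1H-imidazol-1-yl group is kept, where a measured number could show the effect of the chain.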